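Thiosemicarbazone aryl swap: from nitro to chloro

The compounds below may be only part of what the source reports. "The series", "measured", "known", "first", "only" and "open" are said of these compounds alone.

Compound 1 `CC1=CC[C@@H]([C@@](C)(O)CCCC(C)(C)NC(=S)N/N=C\c2ccccc2)CC1` gives 23800 nM in a functional assay on NCI/ADR cells (Homo sapiens) for cytotoxicity, read by sulforhodamine B assay; a lower number here means a stronger inhibitor of growth, a higher number a weaker inhibitor of growth.
Compound 2 `CC1=CC[C@@H]([C@@](C)(O)CCCC(C)(C)NC(=S)N/N=C\c2ccc([N+](=O)[O-])cc2)CC1` reaches only the limit > 100000 nM in this assay.

Compound 2 stands at the top of the two values shown: its result is not a number but (the limit of > 100000 nM in this assay, at which 1 of the 2 values shown sits), so its true position is known only as a range. Among the compounds with values here, the single measured step, an at least 4.2-fold higher number from compound 1 to compound 2 (0.62 log units; beyond the scatter), is the only guide on record, and it runs in the direction of weaker growth inhibition.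

Compound 3 `CC1=CC[C@@H]([C@@](C)(O)CCCC(C)(C)NC(=S)N/N=C\c2ccccc2Cl)CC1` differs from compound 2 by 2-chlorophenyl in place of 4-nitrophenyl on a carbon with a double bond to nitrogen. Within the data shown here, no measured step carries a chlorine on the aromatic ring, so the change is judged from the step between compound 1 and compound 2 read in reverse: removing the nitro group brought the number back to the level of compound 1, and a chlorine is expected to leave compound 3 closer to that level than to the limit of compound 2. Compound 3 is therefore expected to show an at least 3.3-fold lower number from compound 2 to compound 3 (0.52 log units; beyond the scatter) in this assay. The estimate for compound 3 is 30000 nM, with a range from 8000 nM to 100000 nM.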

Compound 3, concentration for total growth inhibition: > 100000 nM
Compound 3: a limit, no number; the forecaster's own chance of this, stated with the estimate: 30%; middle value at least 3.3-fold (0.52 log units) from the limit.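

Compound 3 gives > 100000 nM in this assay, and this is a limit of the assay, not a number. Chloro in place of hydrogen on the aromatic ring gives an at least 4.2-fold higher number from compound 1 to compound 3 (0.62 log units; beyond the scatter), so a second ring substituent, different from the nitro group and carried at a different printed place on the ring, also moves the result away from the measured value of the unsubstituted phenyl compound. The swap from 4-nitrophenyl to 2-chlorophenyl on the carbon with a double bond to nitrogen cannot be read as a step, and compound 1 remains the only one of the three with a measured number, so the ring substituents shown cannot be ranked against each other: the limit of > 100000 nM in this assay, at which 2 of the 3 values shown sit.

Going by these compounds, how far compound 2 and compound 3 lie past that limit stays unknown, as does whether the change in compound 3 follows from the chlorine itself or from where it sits on the ring. The compounds shown also leave open whether an amine or a methoxy group on the aromatic ring would keep a readable number in this assay.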